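Working notes: a 4-formylphenyl analogue of compound 2

A few compounds are considered here, and "the series" means these few. Any claim that something is new, unique, unknown or untested is made for them only; others in the source may bear on it.

Of the compounds shown here, two have been measured so far in a functional assay on SK-OV-3 cells (Homo sapiens) for inhibition, read by CCK-8 assay, with a stated time of 70 h; a lower number here means a stronger inhibitor, a higher number a weaker inhibitor. Compound 1 (`c1ccc(COc2ccc(OCCOCCNC3CCCC3)cc2)cc1`) gives 24800 nM, and compound 2 (`COC(=O)c1cccc(COc2ccc(OCCOCCNC3CCCC3)cc2)c1`) gives 45500 nM. Going by the values given here, compound 2 therefore stands within the scatter of compound 1, its only measured neighbour, and the two values do not separate.

Compound 3 (`O=Cc1ccc(COc2ccc(OCCOCCNC3CCCC3)cc2)cc1`) keeps the shared core and differs from compound 2 in a single place: 4-formylphenyl in place of 3-(methoxycarbonyl)phenyl on a saturated chain carbon bound to an oxygen on an aromatic ring. Among the compounds with values here, no compound carrying a formyl group has been measured, and no measured pair tests a move of a substituent on this ring.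

Within the data shown here, the one measured step that bears on the change is a 1.8-fold higher number from compound 1 to compound 2 (0.26 log units; within the scatter). That step, methoxycarbonyl in place of hydrogen on an aromatic carbon, lies within the scatter. On this thin evidence, no step beyond the scatter is expected in this assay, in either direction. The estimated step is a 1.4-fold lower number from compound 2 to compound 3 (0.15 log units; within the scatter), which also stays within the scatter. For compound 3 the expected value is 32000 nM, with an estimated range of 13000 nM to 75000 nM.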

Compound 3, half-maximal inhibitory concentration: 45000 nM
The estimate for compound 3 lay 1.4-fold (0.15 log units) below the measured number, and the stated range covers the measured number.
By their numbers in this assay, from the lowest: compounds 1, 3 and 2 (each within the scatter of the next).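

In this assay, 4-formylphenyl in place of 3-(methoxycarbonyl)phenyl on a saturated chain carbon bound to an oxygen on an aromatic ring gives no separation (a 1.0-fold lower number from compound 2 to compound 3 (0.00 log units; within the scatter)), so two different substituted phenyl groups at this place now carry values that cannot be told apart. Formyl in place of hydrogen on an aromatic carbon also stays within the scatter (a 1.8-fold higher number from compound 1 to compound 3 (0.26 log units; within the scatter)), as methoxycarbonyl did (a 1.8-fold higher number from compound 1 to compound 2 (0.26 log units; within the scatter)), which places compound 1, compound 2 and compound 3 on one level in this assay. No measured evidence bears on why these three compounds do not separate.

The step from compound 2 to compound 3 changes the group and its place on the ring together, so neither change can be read alone from these compounds. From the compounds shown here alone, whether a carboxylic acid or an aminomethyl group on this ring, or a longer chain at the same place, would give a step beyond the scatter remains open.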